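The source may hold more compounds than are shown below. What is called first, only, known or untested is meant among the compounds shown, and "the series" means these compounds.

Of the compounds shown here, three share one core and have been measured in a functional assay on HeLa cells (Homo sapiens) for antiproliferative activity, read by CCK-8 assay, with a stated time of 72 h, tested at 8 uM; a higher number here means a stronger effect of the compound at the concentration tested, a lower number a weaker effect. Compound 1 `CCN(Cc1ccncc1)C(=S)SCc1ccc(C(=O)Nc2ccccc2N)cc1` gives 77.7% in this assay. Compound 2 `Nc1ccccc1NC(=O)c1ccc(CSC(=S)N2CCN(Cc3ccncc3)CC2)cc1` gives 72.9%, a number that lies within the usual scatter of the result for compound 1. Compound 3 `COc1ccc(N2CCN(C(=S)SCc3ccc(C(=O)Nc4ccccc4N)cc3)CC2)cc1` gives 52.3%, which is clearly lower than the result for compound 1. Among the measured compounds shown here, the only step between two compounds that differ in a single place is a number 20.6 percentage points lower from compound 2 to compound 3 (beyond the scatter), and it concerns the group on the ring amine nitrogen, a different part of the molecule.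

The unmeasured compound 4 `CN(Cc1ccncc1)C(=S)SCc1ccc(C(=O)Nc2ccccc2N)cc1` differs from compound 1 by hydrogen in place of methyl on a saturated chain carbon bound to an amide-type nitrogen. For the measured compounds named here, no measured step changes this part of the molecule, so nothing among the measured compounds shows what this change does. Going by the values given here, the change is small, a single carbon leaving from a chain bound to an amide-type nitrogen, and with no step to argue otherwise the expectation is a result close to that of compound 1, with the step of a number 3.7 percentage points lower from compound 1 to compound 4 (within the scatter) expected to stay within the usual scatter. Compound 4 is therefore estimated to give about 74% in this assay, expected to fall between 58% and 88%.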

Compound 4, a percentage reported as inhibition, at one concentration (the size of the read-out at that concentration, not a potency): 72.7%
The estimate for compound 4 lay 1.3 percentage points above the measured number; measured number inside the range.
By their numbers in this assay, from the lowest: compound 3; then compounds 4, 2 and 1 (each within the scatter of the next).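

Among the compounds shown here, the step of a number 5 percentage points lower from compound 1 to compound 4 (within the scatter) in this assay is the first measured change at this position, and it shows that going from ethyl to methyl, with one carbon leaving, does not move the result beyond the usual scatter of repeated measurements. Within this pair the full ethyl group is therefore not needed to keep the result, and the shorter methyl group serves just as well at the concentration tested. No available evidence explains this tolerance, so the pair describes what happens but does not say why.

As far as these compounds go, how far this position can be changed remains open: a longer chain such as propyl or butyl, a chain carrying a hydroxyl group, or a plain hydrogen on the nitrogen in place of the whole ethyl group could each behave differently, and only ethyl and methyl can be compared here. Each number also comes from a single concentration and gives the size of the effect there rather than a potency, so any difference between ethyl and methyl at other concentrations remains unresolved.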